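The source may hold more compounds than are shown below. What is called first, only, known or untested is meant among the compounds shown, and "the series" means these compounds.

Compound 3 `Cc1cccc(Cn2c(CN3CCN(C(=O)c4ccc(Cl)cc4)CC3)nc3ccccc32)c1` gives 23.2% in an assay on isolated protein for inhibition of aldehyde dehydrogenase 1A1 (Homo sapiens), read by spectrophotometry, tested at 10 uM (a higher number here means more inhibition at the concentration tested (going by the name of the read-out), a lower number less inhibition), the lowest of the three numbers recorded there. Compound 2 `Cc1cccc(Cn2c(CN3CCN(C(=O)C4CCCC4)CC3)nc3ccccc32)c1` gives 67.5% in this assay and compound 1 `Cc1cccc(Cn2c(OC3CCN(C(=O)c4ccco4)CC3)nc3ccccc32)c1` gives 68.3%, both well clear of compound 3 beyond the scatter. Compound 4 `Cc1cccc(Cn2c(CN3CCN(C(=O)C4CCC4)CC3)nc3ccccc32)c1` has not yet been measured; it differs from compound 3 in one place: cyclobutyl in place of 4-chlorophenyl on a carbonyl carbon. For the measured compounds named here, the one measured step that bears on this is a number 44.3 percentage points lower from compound 2 to compound 3 (beyond the scatter), where a carbon-only ring on the same carbonyl carbon was swapped for 4-chlorophenyl and inhibition fell sharply. Reversing that kind of exchange with cyclobutyl is therefore expected to raise inhibition by roughly a number 36.8 percentage points higher from compound 3 to compound 4 (beyond the scatter), because compound 2 gave 67.5%. Compound 4 is estimated at 60%, within 40% to 78%.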

Compound 4, a percentage reported as inhibition, at one concentration (the size of the read-out at that concentration, not a potency): 69.1%
The estimate for compound 4 lay 9.1 percentage points below the measured number, within the range that was stated.
By their numbers in this assay, from the lowest: compound 3; then compounds 2, 1 and 4 (each within the scatter of the next).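

In this assay, cyclobutyl in place of 4-chlorophenyl on a carbonyl carbon gives a number 45.9 percentage points higher from compound 3 to compound 4 (beyond the scatter), so the earlier fall with 4-chlorophenyl is now seen against two different non-aromatic carbon rings. Cyclobutyl in place of cyclopentyl gives a number 1.6 percentage points higher from compound 2 to compound 4 (within the scatter), so these two rings cannot be told apart here, and compound 3 alone stands low among the three amides on this core. Nothing measured here accounts for that gap. The compounds shown leave open whether the drop goes with the aromatic ring or with its chlorine, which plain phenyl would separate, and how cyclopropyl or an open chain such as isopropyl would read on this carbonyl carbon.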